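The source may report more compounds than this note shows. Statements on the series, on what has been measured and on what is new or still open speak of the compounds shown alone.

Values in a physicochemical assay for solubility, measured as kinetic solubility; on this read-out higher numbers stand for higher solubility and lower numbers for lower solubility:

- compound 1 `Cc1cc(-c2noc([C@H](C)NC(=O)c3cc(C(F)(F)F)nn3C)n2)ccn1` gives 179000 nM
- compound 2 `COc1cc(-c2noc([C@H](C)NC(=O)c3cc(C(F)(F)F)nn3C)n2)cc(C)n1` gives 3000 nM
- compound 3 `COCc1cc(-c2noc([C@H](C)NC(=O)c3cc(C(F)(F)F)nn3C)n2)ccn1` gives 200000 nM

Compound 3 and compound 1 share the top of these three values, within the scatter of each other, and compound 2 lies far under both. The next change leads to compound 4 `C[C@H](NC(=O)c1cc(C(F)(F)F)nn1C)c1nc(-c2ccnc(C(F)F)c2)no1`, with difluoromethyl in place of methoxymethyl on an aromatic carbon. Going by the values given here, no measured compound carries difluoromethyl, so the evidence is indirect. The step of a 1.1-fold higher number from compound 1 to compound 3 (0.05 log units; within the scatter) stays within the scatter, while a 60-fold lower number from compound 1 to compound 2 (1.78 log units; beyond the scatter) and a 67-fold higher number from compound 2 to compound 3 (1.82 log units; beyond the scatter) are both large, so a single change of substituent can move this series strongly. Compound 2, at a 60-fold lower number from compound 1 to compound 2 (1.78 log units; beyond the scatter), is the only measured departure from the top values, and it sets the direction and the outer size expected here: a lower number, beyond the scatter but a smaller step than that one. The expected step is an 8.0-fold lower number from compound 3 to compound 4 (0.90 log units; beyond the scatter). For compound 4 the estimated value is 25000 nM, with an expected range from 5000 nM to 120000 nM.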

Compound 4, solubility: 178000 nM
Estimate against measurement, compound 4: 7.1-fold (0.85 log units) below; the measured number lies above the stated range.
By their numbers in this assay, from the lowest: compound 2; then compounds 4, 1 and 3 (each within the scatter of the next).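

Difluoromethyl in place of methoxymethyl, next to the ring nitrogen, does not separate the two compounds in this assay (a 1.1-fold lower number from compound 3 to compound 4 (0.05 log units; within the scatter)), and the same holds for difluoromethyl in place of methyl (a 1.0-fold lower number from compound 1 to compound 4 (0.00 log units; within the scatter)); methyl, methoxymethyl and difluoromethyl are therefore not told apart at this position. Going by these compounds alone, compound 2, which carries methoxy and methyl on this ring, remains the only compound apart from the other three (a 59-fold higher number from compound 2 to compound 4 (1.77 log units; beyond the scatter)), so a large step in this set is no longer a matter of changing just any group here. The data at hand offer no measurement that explains this flat result.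

Going by these compounds, it remains open whether an amine or a carboxylic acid at this position would leave the shared level. Also open, on these data alone, is which of the methoxy and the methyl of compound 2 goes with its low value.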